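One Chloro Becomes Methoxy: Expected Shift in Cytotoxicity

The source may report more compounds than this note shows. Statements on the series, on what has been measured and on what is new or still open speak of the compounds shown alone.

Compound 1 `COc1ccc2[nH]c(-c3ccccc3)c(C(c3c(-c4ccccc4)[nH]c4ccc(C)cc34)C3C(=O)NN=C3C)c2c1`: 1800 nM
Compound 2 `CC1=NNC(=O)C1C(c1c(-c2ccccc2)[nH]c2ccc(Cl)cc12)c1c(-c2ccccc2)[nH]c2ccc(Cl)cc12`: 7000 nM

Going by the values given here, in a functional assay on A549 cells (Homo sapiens) for cytotoxicity, read by MTT assay (a higher number here means a weaker inhibitor, a lower number a stronger inhibitor), compound 2 gives 7000 nM, the highest of the two numbers measured so far. Compound 1 gives 1800 nM, a lower number, and the gap between the two lies beyond the usual scatter. Compound 3 `COc1ccc2[nH]c(-c3ccccc3)c(C(c3c(-c4ccccc4)[nH]c4ccc(Cl)cc34)C3C(=O)NN=C3C)c2c1` differs from compound 2 in one place: methoxy in place of chloro on an aromatic carbon. Compound 3 thus carries one methoxy, as compound 1 does, while it keeps one of the two chloro groups of compound 2. The step of a 2.0-fold lower number from compound 2 to compound 3 (0.30 log units; within the scatter) is expected to go toward a lower number and to exceed the scatter, because compound 1 with a methoxy at this place gives 1800 nM. Compound 3 is therefore estimated at 3500 nM, with a range from 1500 nM to 8000 nM, between the two measured compounds.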

Compound 3, half-maximal inhibitory concentration: 1100 nM
For compound 3 the middle estimate is 3.2-fold (0.50 log units) above the measured one; the measured number lies below the stated range.
By their numbers in this assay, from the lowest: compounds 3 and 1 (each within the scatter of the next); then compound 2.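

In this assay, methoxy in place of chloro on this aromatic carbon gives a 6.4-fold lower number from compound 2 to compound 3 (0.80 log units; beyond the scatter), so the group at this place can move the number beyond the scatter while the other chloro stays where it is. The second substituted place behaves differently in this pair: chloro in place of methyl on an aromatic carbon gives a 1.6-fold lower number from compound 1 to compound 3 (0.21 log units; within the scatter), and with the methoxy present these two groups cannot be told apart in this assay. No measured property of these compounds accounts for either step.

The compounds shown leave open whether an amine, a hydroxyl or a longer chain such as ethoxy on the same aromatic carbon would give a number like that of the methoxy. They also leave open what a second methoxy in place of the remaining chloro would do.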